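Ethylsulfonyl in place of methylsulfonyl on the piperidine

This account rests on a few compounds, and the source may have more. Where it says the series, first, only, none or still open, it means among the compounds named here.

Measured so far:
compound 1 `CC(C)N(CCN(C(=O)Nc1ccc(F)c(F)c1)C1CC[C@]2(c3cccc(C#N)c3)CC2C1)C(C)C`: 2.8 nM
compound 2 `CS(=O)(=O)N1CCC(CN(C(=O)Nc2ccc(F)c(F)c2)C2CC[C@]3(c4cccc(C#N)c4)CC3C2)CC1`: 5.4 nM

In a functional assay for antagonist activity at melanin-concentrating hormone receptor 1 (Homo sapiens) (a higher number here means a weaker inhibitor, a lower number a stronger inhibitor), compound 1 gives 2.8 nM, while compound 2 gives 5.4 nM. Compound 2 sits beside compound 1 on these numbers; the step of a 1.9-fold higher number from compound 1 to compound 2 (0.29 log units; within the scatter) keeps both within the scatter, so neither can be set apart from the other.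

Compound 3 `CCS(=O)(=O)N1CCC(CN(C(=O)Nc2ccc(F)c(F)c2)C2CC[C@]3(c4cccc(C#N)c4)CC3C2)CC1` is the next member. It differs from compound 2 by methyl in place of hydrogen on a saturated chain carbon bound to a sulfonyl sulfur. Going by the values given here, only one measured step exists, and it exchanged the whole side group on the urea nitrogen without moving the number beyond the scatter; no measured step alters a substituent on a sulfonyl sulfur. The change to compound 3 is a far smaller one than that step, so no shift beyond the scatter is expected, estimated as a 1.1-fold lower number from compound 2 to compound 3 (0.03 log units; within the scatter). Compound 3 is therefore expected at about 5 nM, with a range of 2 nM to 13 nM.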

Compound 3, inhibition constant: 21 nM
Beside the measured number, compound 3's estimate is 4.2-fold (0.62 log units) below it; measured number outside the range, above it.
By their numbers in this assay, from the lowest: compounds 1 and 2 (each within the scatter of the next); then compound 3.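

In this assay the group on the sulfonyl sulfur proves sensitive: methylsulfonyl to ethylsulfonyl gives a 3.9-fold higher number from compound 2 to compound 3 (0.59 log units; beyond the scatter) and so lies beyond the scatter, while the far larger exchange of the whole side group in a 1.9-fold higher number from compound 1 to compound 2 (0.29 log units; within the scatter) stayed within it. The two sulfonyl groups therefore do not behave alike against (diisopropylamino)methyl, as 1-(ethylsulfonyl)piperidin-4-yl gives a 7.5-fold higher number from compound 1 to compound 3 (0.88 log units; beyond the scatter) and this too lies beyond the scatter. Nothing available explains why one added methyl has this effect.

On these data alone, whether a longer chain such as propyl on the sulfonyl sulfur raises the number further remains open, as does the outcome with a branched group such as isopropyl or a cyclopropyl ring there. A single pair also cannot show whether the same change would give a similar step on a different side group or core.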